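Dropping a Fluorine from an Aryl Amide Inhibitor

The source may report more compounds than this note shows. Statements on the series, on what has been measured and on what is new or still open speak of the compounds shown alone.

Measured so far:
compound 1, `CC(C#Cc1cccc(C(=O)NCc2ccc(F)cc2C(F)(F)F)c1)N(O)C(N)=O`: 1300 nM
compound 2, `CC(C#Cc1cccc(C(=O)NCCC(c2ccccc2)c2ccc(F)cc2)c1)N(O)C(N)=O`: 160 nM

Of the compounds shown here, two have been tested in an assay for inhibition of Polyunsaturated fatty acid 5-lipoxygenase (Homo sapiens), read by HPLC, with stated times of 15 min and 10 min; a lower number here means a stronger inhibitor, a higher number a weaker inhibitor. Compound 1 gives the highest number of the two, and the nearest neighbour, compound 2, gives a lower number, a gap that lies beyond the usual scatter of repeated measurements. Going by the values given here, no single-point step links the two measured compounds.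

The next compound, compound 3 `CC(C#Cc1cccc(C(=O)NCc2ccccc2C(F)(F)F)c1)N(O)C(N)=O`, is derived from compound 1 by a small change: hydrogen in place of fluoro on an aromatic carbon. Only a fluorine atom disappears; everything else in the molecule stays as it is. Among the compounds with values here, with no measured step of this kind to lean on, the expectation is that the step from compound 1 to compound 3 is small, a 1.2-fold higher number from compound 1 to compound 3 (0.06 log units; within the scatter), in either direction and not beyond the scatter. Compound 3 is therefore estimated to give 1500 nM in this assay, with a range from 600 nM to 4000 nM.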

Compound 3, half-maximal inhibitory concentration: 700 nM
Beside the measured number, compound 3's estimate is 2.1-fold (0.33 log units) above it; measured number inside the range.
By their numbers in this assay, from the lowest: compound 2; then compounds 3 and 1 (each within the scatter of the next).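

In this assay, putting hydrogen in place of fluoro on the aromatic carbon meta to a trifluoromethyl group and para to a large group gives a 1.9-fold lower number from compound 1 to compound 3 (0.27 log units; within the scatter). Going by these compounds alone, this is the first measured step that changes a single place, and it lies within the scatter, so compound 1 and compound 3 cannot be told apart in this assay. At this position, then, the fluorine can be lost without a measurable effect on inhibition. Nothing available explains this result.

Still open, from the compounds shown here alone, is whether a larger group at this same position, such as chlorine, a methoxy group or an amine, would shift the number beyond the scatter. Going by these compounds, the role of the trifluoromethyl group also remains unknown, and replacing it with a plain methyl group would test that.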